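Shortening a long chain on a nucleoside-like core

The source may hold more compounds than are shown below. What is called first, only, known or untested is meant among the compounds shown, and "the series" means these compounds.

Compound 1 `CCCCCCCCCCCCNc1nc(O)c2ncnc-2c(O)n1` and compound 2 `CCCCCCCCCCCCCCCCNc1nc(=O)c2ncn([C@@H]3O[C@H](CO)[C@@H](O)[C@H]3O)c2c(=O)[nH]1` share a core bearing a long saturated chain on a ring nitrogen. In an assay on isolated protein for inhibition of ATP-dependent RNA helicase SUPV3L1, mitochondrial (Homo sapiens) (on this read-out higher numbers stand for weaker inhibition and lower numbers for stronger inhibition), compound 1 gives only a limit of the assay, > 500 ug/mL. Compound 2 likewise reaches only a limit in this assay, > 500 ug/mL, so both values sit at the limit of > 500 ug/mL in this assay, at which 2 of the 2 values shown sit, and no direction can be read from them. Compound 3 `CCCCCCCCCCNc1nc(=O)c2ncn([C@@H]3O[C@H](CO)[C@@H](O)[C@H]3O)c2c(=O)[nH]1` differs from compound 2 by hydrogen in place of hexyl on a saturated chain carbon, ten or more bonds along the chain from a nitrogen on an aromatic ring. The step from compound 2 to compound 3 is expected to be a step that the limit leaves unreadable from compound 2 to compound 3, likely still a limit. Compound 3 is estimated at 600 ug/mL, between 250 ug/mL and 1500 ug/mL.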

Compound 3, half-maximal inhibitory concentration: > 500 ug/mL
Compound 3: a limit, no number; the forecaster's own chance of this, stated with the estimate: 75%; the middle value lies beyond the limit too.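

Compound 2 and compound 3 both stop at a limit of the assay, so no step in strength can be read between them: the limit of > 500 ug/mL in this assay, at which 3 of the 3 values shown sit.

The compounds shown leave open whether any chain length on the shared core gives a measurable inhibition value.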